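Sulfonyl groups on the ring nitrogen of the core

The source may report more compounds than this note shows. Statements on the series, on what has been measured and on what is new or still open speak of the compounds shown alone.

Compound 1 `COc1ccc(-c2cc(=O)c3c(OC)cc(OC)cc3n2C)cc1` gives 30000 nM in a functional assay on KOPN-8 cells (Homo sapiens) for antiproliferative activity, with a stated time of 72 h; a lower number here means that less compound is needed, a higher number that more compound is needed for the effect. Compound 2 `COc1ccc(-c2cc(=O)c3c(OC)cc(OC)cc3n2S(=O)(=O)c2ccc(Br)cc2)cc1` reaches only a limit, > 86200 nM. Compound 3 `COc1ccc(-c2cc(=O)c3c(OC)cc(OC)cc3n2S(=O)(=O)c2ccc(C)cc2)cc1` likewise reaches only a limit, > 44800 nM. Compound 3 thus stands at the ceiling of this assay, with an at least 1.4-fold higher number from compound 1 to compound 3 (0.17 log units; that floor lies within the scatter) beside an at least 2.8-fold higher number from compound 1 to compound 2 (0.45 log units; beyond the scatter); the step that the two limits leave unreadable from compound 2 to compound 3 cannot be read because the limit of > 44800 nM in this assay, at which 1 of the 3 values shown sits, and the limit of > 86200 nM in this assay, at which 1 of the 3 values shown sits, cap both ends. Compound 4 `COc1ccc(-c2cc(=O)c3c(OC)cc(OC)cc3n2S(=O)(=O)Cc2ccccc2)cc1` carries benzyl in place of 4-methylphenyl on a sulfonyl sulfur. Among the compounds with values here, both sulfonyl analogues end in limits, so no measured step resolves a benzyl against a 4-methylphenyl on the sulfonyl sulfur; in this assay no step beyond the scatter is expected. Compound 4 is expected at 60000 nM, between 20000 nM and 200000 nM, most likely again only a limit. The expected step is a step that the limit leaves unreadable from compound 3 to compound 4.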

Compound 4, half-maximal effective concentration: > 34400 nM
Compound 4: a limit, no number; the forecaster's own chance of this, stated with the estimate: 75%; the middle value lies beyond the limit too.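

With benzyl in place of 4-methylphenyl on the sulfonyl sulfur, compound 4 gives > 34400 nM in this assay as a limit and not a number, so a third sulfonyl group on the aromatic nitrogen also ends in a limit. The steps to compound 4 from compound 2 and from compound 3 cannot be read, each joining two limits. Benzylsulfonyl in place of methyl gives an at least 1.1-fold higher number from compound 1 to compound 4 (0.05 log units; that floor lies within the scatter) and so adds only a floor.

From the compounds shown here alone, whether any sulfonyl group here yields a measured number stays open. So does whether a longer chain or an amine on the aromatic nitrogen would improve on compound 1.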